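Pyrazole chalcone series: amino-to-dimethoxy exchange on the ketone

A few compounds are considered here, and "the series" means these few. Any claim that something is new, unique, unknown or untested is made for them only; others in the source may bear on it.

Measured compounds:
compound 1, `COc1cc(-c2cc(/C=C/C(=O)c3ccc(N)cc3)[nH]n2)cc(OC)c1OC`, > 100000 nM
compound 2, `COc1ccc(-c2cc(/C=C/C(=O)c3ccc(OC)c(OC)c3)[nH]n2)cc1`, 24900 nM
compound 3, `COc1ccc(-c2cc(/C=C/C(=O)c3ccc(N)cc3)[nH]n2)cc1`, 85800 nM

In a functional assay on T47D cells (Homo sapiens) for inhibition, read by sulforhodamine B assay, with a stated time of 48 h (on this read-out higher numbers stand for lower toxicity in this test and lower numbers for higher toxicity in this test), compound 1 gives only a limit, > 100000 nM, so its place among the three is not fixed by a number. The other two carry numbers: in this assay compound 2 gives 24900 nM and compound 3 gives 85800 nM. Among the measured compounds shown here, no single-change step between measured compounds is available, so the effect of any one change is not pinned down; what the two numbered compounds show is that compound 3, which carries the 4-aminophenyl, sits at a higher value than compound 2, which carries the 3,4-dimethoxyphenyl.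

Compound 4, `COc1ccc(C(=O)/C=C/c2cc(-c3cc(OC)c(OC)c(OC)c3)n[nH]2)cc1OC`, is not yet measured. It differs from compound 1 in one place: 3,4-dimethoxyphenyl in place of 4-aminophenyl on a carbonyl carbon. Since compound 1 sits at a limit, (the limit of > 100000 nM in this assay, at which 1 of the 3 values shown sits), the starting point is itself open. The expectation for the step from compound 1 to compound 4 in this assay is toward a lower value, that is toward higher toxicity in this test, by an amount beyond the usual scatter, an at least 2.5-fold lower number from compound 1 to compound 4 (0.39 log units; beyond the scatter), in the direction that the values of compound 2 and compound 3 suggest. For compound 4 the estimate in this assay is 40000 nM, expected to lie between 15000 nM and 150000 nM.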

Compound 4, concentration lethal to 50% of the cells: > 100000 nM
Compound 4: only a limit was reported; the forecaster's own chance of this, stated with the estimate: 25%; at least 2.5-fold (0.39 log units) between middle value and limit.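

In this assay compound 1 and compound 4 both stand at a limit and not at a number, so no step between them can be read: the limit of > 100000 nM in this assay, at which 2 of the 4 values shown sit.

As far as these compounds go, whether 3,4-dimethoxyphenyl in place of 4-aminophenyl on a carbonyl carbon shifts the value at all on the core of compound 1, and by how much, stays open.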